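From a Pyrazolyl Amide to an Isopropyl Amide

This account rests on a few compounds, and the source may have more. Where it says the series, first, only, none or still open, it means among the compounds named here.

Of the compounds shown here, three have so far been measured in an assay on HEK293 cells for agonist activity at transient receptor potential cation channel subfamily M member 8 (Homo sapiens), read by fluorescence and calcium flux, with a stated time of 15 min; on this read-out higher numbers stand for an effect only at larger amounts of compound and lower numbers for an effect already at smaller amounts. Compound 1 `Cc1ccc(OCC(=O)N(Cc2cccs2)c2ccn(C)n2)cc1` gives 855 nM in this assay, the highest of the two numbers recorded. Compound 2 `CCN(Cc1cccs1)C(=O)COc1ccc(C(C)C)cc1` gives 397 nM, a lower number than compound 1, and the gap between the two lies beyond the scatter. Compound 3 `CCN(Cc1ccncc1)C(=O)COc1ccc(C)cc1` gives "not active" (no number reported) in this assay, with no number given.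

The account now turns to compound 4 `Cc1ccc(OCC(=O)N(Cc2cccs2)C(C)C)cc1`, which has not yet been measured. Compared with compound 1 the difference is isopropyl in place of 1-methyl-1H-pyrazol-3-yl on an amide-type nitrogen. For the measured compounds named here, no pair of measured compounds differs in exactly this way, so the size of the step cannot be read directly from the data. Compound 2, which carries a saturated chain on its amide-type nitrogen, gives 397 nM, which suggests that an alkyl group at that position is tolerated. For compound 4 the estimate implies a step of a 1.4-fold lower number from compound 1 to compound 4 (0.15 log units; within the scatter), a modest expected move toward a lower number. Compound 4 is estimated at 600 nM, with an expected range from 200 nM to 2000 nM.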

Compound 4, half-maximal effective concentration: 70 nM
The estimate for compound 4 lay 8.6-fold (0.93 log units) above the measured number; the measured number lies below the stated range.
By their numbers in this assay, from the lowest: compound 4; then compound 2; then compound 1.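

In this assay the amide-type nitrogen proves to be a sensitive position, since isopropyl in place of 1-methyl-1H-pyrazol-3-yl gives a 12-fold lower number from compound 1 to compound 4 (1.09 log units; beyond the scatter) on an otherwise unchanged core. The earlier compounds shown here offered no pair differing only here, and this step now shows that the five-membered aromatic ring is not needed at this nitrogen for a low number on this read-out. Nothing available explains why the step is so large.

The compounds shown leave open how a longer chain such as n-butyl, or a cyclopropyl ring, would compare with isopropyl on this nitrogen. They also do not tell whether an amine or a carboxylic acid carried on that alkyl group would keep the low number of compound 4.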